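The source may hold more compounds than are shown below. What is called first, only, known or untested is meant among the compounds shown, and "the series" means these compounds.

Compound 1, with the structure `CC(C)Sc1nc(O)cc(C(C)c2ccccc2)n1`, is tested in a functional assay on MT4 cells (Homo sapiens) for cytotoxicity (on this read-out higher numbers stand for lower toxicity in this test and lower numbers for higher toxicity in this test), where compound 1 gives only a limit of the assay, > 200000 nM. Compound 2, with the structure `CCC(c1ccccc1)c1cc(O)nc(SC(C)C)n1`, likewise gives only a limit in this assay, > 200000 nM. The change between them is methyl in place of hydrogen on a saturated chain carbon, two bonds along the chain from two aromatic carbons, and the step that the two limits leave unreadable from compound 1 to compound 2 stays unreadable, since both values sit at the limit of > 200000 nM in this assay, at which 2 of the 3 values shown sit. Among the compounds with values here, compound 3, with the structure `CC(C)Sc1nc(O)cc(C(C)c2c(Cl)cccc2Cl)n1`, gives the only plain number in this assay, 117000 nM. How the cores of compound 1 and compound 3 differ is not broken down here.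

Compound 4, with the structure `CCC(c1cc(O)nc(SC(C)C)n1)c1c(Cl)cccc1Cl`, is yet to be measured in this assay. It differs from compound 3 by methyl in place of hydrogen on a saturated chain carbon, two bonds along the chain from two aromatic carbons, the same change made from compound 1 to compound 2, at the same place. Because the earlier step that the two limits leave unreadable from compound 1 to compound 2 gives no readable size, the expectation for compound 4 rests mainly on compound 3 and its value 117000 nM, with a step of a 1.1-fold higher number from compound 3 to compound 4 (0.05 log units; within the scatter) expected to be small. Compound 4 is therefore estimated at 130000 nM in this assay, expected between 60000 nM and 260000 nM.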

Compound 4, half-maximal cytotoxic concentration: > 200000 nM
Compound 4 was reported as a limit; the forecaster's own chance of this, stated with the estimate: 30%; middle value at least 1.5-fold (0.18 log units) from the limit.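

In this assay, methyl in place of hydrogen on the core of compound 3 gives an at least 1.7-fold higher number from compound 3 to compound 4 (0.23 log units; that floor lies within the scatter). Compound 4 gives only a limit, > 200000 nM, so that step is a floor and not a measured size, and the floor itself does not clear the usual scatter. The same change on the core of compound 1 cannot be read, so the two cores show no conflict, but nothing here shows that the size of the step carries from one core to the other, and the values in this series crowd at one end of the read-out: the limit of > 200000 nM in this assay, at which 3 of the 4 values shown sit.

Open, going by these compounds, is how a longer chain, such as propyl, or an amine in place of the methyl on that saturated chain carbon would read in this assay. Also open, on these data alone, is how far past the limit compound 2 and compound 4 really lie, which a wider concentration range could settle.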